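Methyl on the Benzyl Group of a Triazole-Linked Flavanone

This account rests on a few compounds, and the source may have more. Where it says the series, first, only, none or still open, it means among the compounds named here.

Measured so far:
Compound 1, `COc1ccc([C@@H]2CC(=O)c3c(O)cc(OCc4cn(C5CCCC5)nn4)cc3O2)cc1O` — 10500 nM
Compound 2, `COc1ccc([C@@H]2CC(=O)c3c(O)cc(OCc4cn(Cc5ccccc5)nn4)cc3O2)cc1O` — 11000 nM

In a functional assay on RAW264.7 cells (Mus musculus) for inhibition, read by Griess assay, with stated times of 2 h and 24 h (on this read-out higher numbers stand for weaker inhibition and lower numbers for stronger inhibition), compound 1 gives 10500 nM, and compound 2 gives 11000 nM. Compound 2 holds the highest of the two numbers shown, but the only measured step, a 1.0-fold higher number from compound 1 to compound 2 (0.02 log units; within the scatter), lies within the scatter, so the two compounds cannot be ordered.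

Compound 3, `COc1ccc([C@@H]2CC(=O)c3c(O)cc(OCc4cn(Cc5ccccc5C)nn4)cc3O2)cc1O`, differs from compound 2 by methyl in place of hydrogen on an aromatic carbon. Going by the values given here, no measured step shows a methyl entering anywhere; the one step in hand, a change of the group on the aromatic nitrogen, moved the number hardly at all. An expected step of no change at the digits printed from compound 2 to compound 3 (within the scatter) in this assay, no larger than the scatter, therefore follows. Compound 3 is estimated at 11000 nM, within 5000 nM to 25000 nM.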

Compound 3, half-maximal inhibitory concentration: 13100 nM
Compound 3: the middle estimate sits 1.2-fold (0.08 log units) below what was measured, and the stated range covers the measured number.
By their numbers in this assay, from the lowest: compounds 1, 2 and 3 (each within the scatter of the next).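

In this assay, methyl on the benzyl group, giving 2-methylbenzyl, brings only a small step (a 1.2-fold higher number from compound 2 to compound 3 (0.08 log units; within the scatter)), so this place on the ring accepts a methyl with no change that can be told from the scatter. The step from cyclopentyl to 2-methylbenzyl on the aromatic nitrogen is also small (a 1.2-fold higher number from compound 1 to compound 3 (0.10 log units; within the scatter)), which leaves all three groups unordered. Nothing at hand bears on these results.

On these data alone, whether a chlorine, a methoxy or a carboxylic acid in the same place would move the number remains open, as does the effect of an amine or a longer chain on the aromatic nitrogen.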